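Compounds 1 to 3 and the indolyl step to compound 4

The compounds below may be only part of what the source reports. "The series", "measured", "known", "first", "only" and "open" are said of these compounds alone.

Measured in a functional assay on DU-145 cells (Homo sapiens) for inhibition, read by trypan blue exclusion, with a stated time of 96 h (on this read-out lower numbers stand for stronger inhibition of growth and higher numbers for weaker inhibition of growth), so far
compound 1 `O=C(/C(=C\c1ccc(Cl)c([N+](=O)[O-])c1)S(=O)(=O)c1ccc(Br)cc1)c1ccc(Br)cc1` gives 10000 nM in this series
compound 2 `O=C(/C(=C\c1c[nH]c2ccccc12)Sc1ccc(Br)cc1)c1ccc(Br)cc1` gives 1000 nM in this series
compound 3 `O=C(/C(=C\c1ccc(I)cc1)S(=O)(=O)c1ccc(Br)cc1)c1ccc(Br)cc1` gives 1000 nM in this series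

Compound 3 with 1000 nM stands level with compound 2, and the two share the lowest number of the three. The next structure is compound 4 `O=C(/C(=C\c1c[nH]c2ccccc12)S(=O)(=O)c1ccc(Br)cc1)c1ccc(Br)cc1` and the change is 1H-indol-3-yl in place of 4-iodophenyl on a double-bonded chain carbon bound to a double-bonded chain carbon. Within the data shown here, the only measured step at this place is a 10-fold lower number from compound 1 to compound 3 (1.00 log units; beyond the scatter) and it shows that this place can move the number, but it involves a different pair of groups. Compound 2 carries 1H-indol-3-yl at the same place and gives 1000 nM on a core that differs from that of compound 4. No step beyond the scatter is therefore expected in this assay for this change, although the evidence is thin. The expected outcome is no change at the digits printed from compound 3 to compound 4 (within the scatter) on present data. Compound 4 is estimated at 1000 nM with an expected range from 200 nM to 5000 nM for now.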

Compound 4, concentration for 50% growth inhibition: 25000 nM
Compound 4: middle estimate off by 25-fold (1.40 log units), on the low side, and the stated range ends below it.
By their numbers in this assay, from the lowest: compounds 2 and 3 (each within the scatter of the next); then compound 1; then compound 4.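

In this assay, the place on a double-bonded chain carbon bound to a double-bonded chain carbon can also move the number upward: 1H-indol-3-yl in place of 4-iodophenyl gives a 25-fold higher number from compound 3 to compound 4 (1.40 log units; beyond the scatter), and in place of 4-chloro-3-nitrophenyl it gives a 2.5-fold higher number from compound 1 to compound 4 (0.40 log units; beyond the scatter). The reading for 1H-indol-3-yl does not carry over from compound 2, since (4-bromophenyl)sulfonyl in place of (4-bromophenyl)sulfanyl gives a 25-fold higher number from compound 2 to compound 4 (1.40 log units; beyond the scatter). No measurement at hand bears on the reason for these steps.

Going by these compounds, it remains open whether the change from (4-bromophenyl)sulfanyl to (4-bromophenyl)sulfonyl has a similar effect with 4-iodophenyl at this place. On these data alone, it is also open how an amine or a carboxylic acid on the phenyl ring at this place would read.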